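Replacing 3-chloro-4-fluorophenyl with cyclohexyl: working notes on the series

The source may hold more compounds than are shown below. What is called first, only, known or untested is meant among the compounds shown, and "the series" means these compounds.

Values so far in an in vitro ADME assay on microsomes from liver (Homo sapiens) for metabolic stability, tested at 1 uM; a lower number here means that the compound disappears faster, a higher number that the compound lasts longer (half-life):
- compound 1 `CS(=O)(=O)Nc1ccc2c(c1)S(=O)(=O)N=C(C1=C(O)[C@@H]3[C@H]4CC[C@H](C4)[C@@H]3N(Cc3ccccc3F)C1=O)N2` gives > 1 h (a limit)
- compound 2 `CS(=O)(=O)Nc1ccc2c(c1)S(=O)(=O)N=C(C1=C(O)[C@@H]3[C@H]4CC[C@H](C4)[C@@H]3N(Cc3ccc(F)c(Cl)c3)C1=O)N2` gives > 1 h (a limit)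

Compound 2 stands only at a limit (> 1 h) and has no number. The series as a whole shows the limit of > 1 h in this assay, at which 2 of the 2 values shown sit, and nothing finer.

Compound 3 `CS(=O)(=O)Nc1ccc2c(c1)S(=O)(=O)N=C(C1=C(O)[C@@H]3[C@H]4CC[C@H](C4)[C@@H]3N(CC3CCCCC3)C1=O)N2` differs from compound 2 by cyclohexyl in place of 3-chloro-4-fluorophenyl on a saturated chain carbon bound to an amide-type nitrogen in a ring and so has cyclohexyl in place of 3-chloro-4-fluorophenyl.

Going by the values given here, the one measured step at this place is a step that the two limits leave unreadable from compound 1 to compound 2 and it gives no size to carry over. In this assay no firm direction can be read from it, and any change may stay within the scatter.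

The expected step is a number no higher from compound 2 to compound 3 (the limit leaves the size open) and this remains a loose estimate.

For compound 3 the expected half-life is 1 h within an estimated range of 0.4 h to 2 h and a report as a limit is about as likely as a number.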

Compound 3, half-life: 0.733 h
The estimate for compound 3 lay 1.4-fold (0.13 log units) above the measured number; low and high end bracket the measured number.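

In this assay compound 3 gives the series its first number rather than a limit, so a change at this place, on a saturated chain carbon bound to an amide-type nitrogen in a ring, can now be given a minimum size. Cyclohexyl in place of 3-chloro-4-fluorophenyl reads as an at least 1.3-fold lower number from compound 2 to compound 3 (0.13 log units; that floor lies within the scatter), and cyclohexyl in place of 2-fluorophenyl reads as an at least 1.3-fold lower number from compound 1 to compound 3 (0.13 log units; that floor lies within the scatter). Both floors lie within the scatter, so neither step yet fixes a firm direction, and the rest of the series offers no number to compare: the limit of > 1 h in this assay, at which 2 of the 3 values shown sit.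

Going by these compounds, the step between the two aromatic groups still cannot be read, so the true distance of compound 1 and compound 2 from compound 3 remains open. Also open, on these data alone, is whether a hydroxyl group or an amine on the cyclohexyl ring, or a longer chain in its place, would stay close to compound 3.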